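Swapping the carbamate for a sulfamide on the piperidine

The source may hold more compounds than are shown below. What is called first, only, known or untested is meant among the compounds shown, and "the series" means these compounds.

Of the compounds shown here, two have been measured in a functional assay on CHO-K1 cells with Glucose-dependent insulinotropic receptor (Homo sapiens) as the target, read by a luciferase reporter, with a stated time of 5 h; a lower number here means a smaller maximal response, a higher number a larger maximal response. Compound 1 `CC(C)OC(=O)N1CCC(Oc2cccc3c2CCN3c2ccc(S(C)(=O)=O)cc2)CC1` reaches 70% in this assay. Compound 2 `CS(=O)(=O)c1ccc(N2CCc3c(OC4CCN(C(=O)OCCF)CC4)ncnc32)c(F)c1` reaches 86% in this assay, the larger of the two maximal responses, and its distance from compound 1 lies beyond the usual scatter.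

Compound 3 `CN(C)S(=O)(=O)N1CCC(Oc2ncnc3c2CCN3c2ccc(S(C)(=O)=O)cc2F)CC1` keeps the core of compound 2 and differs from it in one place: dimethylsulfamoyl in place of (2-fluoroethoxy)carbonyl on an amine nitrogen in a ring. For the measured compounds named here, no pair of measured compounds differing in a single spot is available, so the size of this step has to be judged from the change itself. The groups that leave and enter are of the same size and carry the same number of acceptors, so the step from compound 2 to compound 3 in this assay is expected to be small, within the scatter, with no clear direction: a number 2 percentage points lower from compound 2 to compound 3 (within the scatter). Compound 3 is therefore estimated to reach 84% in this assay, between 64% and 104%.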

Compound 3, largest response reached (reported as percent of maximum), in percent of the reference or control that the assay uses: 68%
For compound 3 the middle estimate is 16 percentage points above the measured one, and the stated range covers the measured number.
By their numbers in this assay, from the lowest: compounds 3 and 1 (each within the scatter of the next); then compound 2.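

At this position, the amine nitrogen of the six-membered ring, the change to dimethylsulfamoyl in this assay is a number 18 percentage points lower from compound 2 to compound 3 (beyond the scatter). The position is therefore not indifferent to the group it carries. Matching counts of heavy atoms and hydrogen-bond acceptors in the leaving and entering groups did not keep the maximal response level, and no supporting measurement here accounts for the drop.

With a single step at this position, the compounds shown leave open whether the lower response goes with the sulfamide as a whole, with its two methyl groups, or with the loss of the (2-fluoroethoxy)carbonyl group. An acetyl group or a dimethylcarbamoyl group on the same nitrogen would help tell these readings apart.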